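The source may report more compounds than this note shows. Statements on the series, on what has been measured and on what is new or still open speak of the compounds shown alone.

Measured so far:
- compound 1 `N[C@H]1CC[C@H](Nc2c(C(=O)NCc3ccc(F)cc3)nc(N3CCCCS3(=O)=O)c3cccnc23)CC1`: > 10000 nM (a limit)
- compound 2 `N[C@H]1CC[C@H](Nc2c(C(=O)NCc3ccco3)nc(Br)c3cccnc23)CC1`: > 10000 nM (a limit)

In a functional assay on HCT-116 cells (Homo sapiens) for cytotoxicity, read by MTT assay, with a stated time of 72 h (a lower number here means a stronger inhibitor, a higher number a weaker inhibitor), compound 2 gives > 10000 nM, which is a limit and not a number. Compound 3 `N[C@H]1CC[C@H](Nc2c(C(=O)NCc3ccc(Cl)cc3)nc(Br)c3cccnc23)CC1` differs from it by one change: 4-chlorophenyl in place of furan-2-yl on a saturated chain carbon bound to an amide-type nitrogen. In words, 4-chlorophenyl takes the place of furan-2-yl on a saturated chain carbon bound to an amide-type nitrogen. Going by the values given here, no measured pair shows what such a swap does in this assay. A small move towards stronger inhibition is expected, or none beyond the scatter, because of the limit of > 10000 nM in this assay, at which 2 of the 2 values shown sit. The expected step runs an at least 1.2-fold lower number from compound 2 to compound 3 (0.09 log units; that floor lies within the scatter). For compound 3 the estimate is 8000 nM, with an expected range of 2000 nM to 20000 nM.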

Compound 3, half-maximal inhibitory concentration: 4000 nM
Compound 3: the middle estimate sits 2.0-fold (0.30 log units) above what was measured; the measured number falls inside the stated range.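

In this assay, the group on the saturated chain carbon bound to an amide-type nitrogen proves able to shift the read-out: 4-chlorophenyl in place of furan-2-yl gives an at least 2.5-fold lower number from compound 2 to compound 3 (0.39 log units; beyond the scatter). Going by these compounds alone, the earlier compounds showed no measurable number, so this is the first sign that this place matters. The step is only a floor, since the value for compound 2 is a limit and not a number: the limit of > 10000 nM in this assay, at which 2 of the 3 values shown sit.

Going by these compounds, whether the chlorine or the six-membered aromatic ring carries the step stays open. So does what a plain phenyl or a 4-methoxyphenyl would give at this place.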